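The compounds below may be only part of what the source reports. "The series", "measured", "known", "first", "only" and "open" are said of these compounds alone.

Series notes. In a functional assay on CHO cells for agonist activity at Free fatty acid receptor 1 (Homo sapiens), read by FLIPR and calcium flux, tested at 100 nM (a higher number here means a stronger effect of the compound at the concentration tested, a lower number a weaker effect), compound 1 `O=C(O)CC1COc2cc(OCc3nnc(-c4ccccc4)s3)ccc21` gives 3.36%, compound 2 `Cc1nc(-c2ccccc2)sc1COc1ccc2c(c1)OCC2CC(=O)O` gives 54.8% and compound 3 `Cc1cc(COc2ccc3c(c2)OCC3CC(=O)O)nn1-c1ccccc1` gives 0.98%. Compound 2 stands highest of the three numbers in this assay; its nearest neighbour is compound 1, beyond the scatter, and compound 3 lies furthest, also beyond the scatter. Compound 4 `Cc1nc(-c2cccc(Cl)c2)sc1COc1ccc2c(c1)OCC2CC(=O)O` has not yet been measured. It differs from compound 2 in one place: chloro in place of hydrogen on an aromatic carbon. Within the data shown here, no step between measured compounds covers this change, so the expectation rests on the number of compound 2 alone. The step of a number 7.2 percentage points higher from compound 2 to compound 4 (within the scatter) is estimated to be small and upward, within the scatter. In this assay compound 4 is expected to give 62%, with a range from 40% to 82%.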

Compound 4, a percentage reported as activity, at one concentration (the size of the read-out at that concentration, not a potency): 43%
Beside the measured number, compound 4's estimate is 19 percentage points above it, within the range that was stated.
By their numbers in this assay, from the lowest: compounds 3 and 1 (each within the scatter of the next); then compound 4; then compound 2.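

In this assay, among these compounds, the change from phenyl to 3-chlorophenyl gives a number 11.8 percentage points lower from compound 2 to compound 4 (beyond the scatter) and is the only step read with the rest of the structure held fixed. It shows that chloro on this aromatic carbon lowers the read-out modestly and does not abolish it. Nothing available bears on the reason for this step.

As far as these compounds go, it remains open whether fluoro, methoxy or a nitrile on this same carbon would give a step of similar size and direction. This single pair also leaves open whether chloro would act alike on another carbon of this ring.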